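The compounds below may be only part of what the source reports. "The series", "measured", "known", "first", "only" and "open" are said of these compounds alone.

Compound 1 `c1ccc2[nH]c(-n3cccn3)cc2c1` is the starting point of this step. In a functional assay on PC-3 cells (Homo sapiens) for cytotoxicity, read by MTT assay, with a stated time of 72 h (a lower number here means a stronger inhibitor, a higher number a weaker inhibitor), compound 1 gives > 100000 nM, which is a limit of the assay rather than a measured number. Two further compounds were run in the same way. Compound 2 `COc1ccc2[nH]c3c(c4c(c5ccnn53)C(=O)NC4=O)c2c1` gives > 100000 nM in this assay, again only a limit. Compound 3 `Cc1ccc2[nH]c3c4cn[nH]c4c4c(c3c2c1)C(=O)NC4=O` gives > 100000 nM in this assay, also a limit. Every value shown so far therefore sits at the same place, summed up as the limit of > 100000 nM in this assay, at which 3 of the 3 values shown sit, and compound 1 cannot be placed above or below either neighbour, since none of the three has a number at all.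

Compound 4 `COc1ccc2[nH]c(-n3cccn3)cc2c1` has not yet been measured in this assay. It differs from compound 1 in one place: methoxy in place of hydrogen on an aromatic carbon. Within the data shown here, no step between two measured compounds is available to show what this kind of change does here, so the expectation rests on the three limits alone. Among the measured compounds shown here, for compound 4 the expected step is a step that the limit leaves unreadable from compound 1 to compound 4, essentially no movement beyond the scatter, because the only evidence is the limit of > 100000 nM in this assay, at which 3 of the 3 values shown sit. Compound 4 is accordingly expected to give about 150000 nM, within a range from 40000 nM to 600000 nM, and the assay will most likely again report only its limit.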

Compound 4, half-maximal inhibitory concentration: > 100000 nM
Compound 4 ended at the assay's limit (the forecaster's own chance of this, stated with the estimate: 85%); the middle value is on the limit's open side.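

Compound 1 and compound 4 both end at a limit of the assay rather than at a number, so the step from hydrogen to methoxy on an aromatic carbon cannot be read: the limit of > 100000 nM in this assay, at which 4 of the 4 values shown sit.

The compounds shown leave open whether any structural change among them shifts activity in this assay, as none has yet given an actual number.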